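Taking the chloro group off the benzyl sulfonyl analogue

The source may hold more compounds than are shown below. What is called first, only, known or untested is meant among the compounds shown, and "the series" means these compounds.

compound 1 `CC1(C(=O)NS(=O)(=O)c2ccc(Cl)s2)CCN(c2nc3c(cc2C#N)C(=O)OC3)CC1` gives 1640 nM
compound 2 `CC1(C(=O)NS(=O)(=O)Cc2ccc(F)cc2)CCN(c2nc3c(cc2C#N)C(=O)OC3)CC1` gives 35400 nM
compound 3 `CC1(C(=O)NS(=O)(=O)Cc2ccc(Cl)cc2)CCN(c2nc3c(cc2C#N)C(=O)OC3)CC1` gives 3010 nM

All three values come from a functional assay (Platelet, plasma) for inhibition, with Homo sapiens as the target (a higher number here means a weaker inhibitor, a lower number a stronger inhibitor), and are read here as one set. On these numbers compound 3 stands level with the 5-chlorothiophen-2-yl analogue (a 1.8-fold higher number from compound 1 to compound 3 (0.26 log units; within the scatter)) and far from the 4-fluorobenzyl analogue (a 12-fold lower number from compound 2 to compound 3 (1.07 log units; beyond the scatter)).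

Next comes compound 4 `CC1(C(=O)NS(=O)(=O)Cc2ccccc2)CCN(c2nc3c(cc2C#N)C(=O)OC3)CC1` with the change hydrogen in place of chloro on an aromatic carbon as its only difference, hydrogen in place of chloro on an aromatic carbon, so that 4-chlorobenzyl becomes benzyl.

Among the compounds with values here, the closest evidence is the one exchange measured at that same carbon (a 12-fold lower number from compound 2 to compound 3 (1.07 log units; beyond the scatter)), and it is large. The step of a 22-fold higher number from compound 1 to compound 2 (1.33 log units; beyond the scatter) is large as well, whereas a 1.8-fold higher number from compound 1 to compound 3 (0.26 log units; within the scatter) is not, so the outcome follows the group on the benzyl ring in these three compounds. Within the data shown here, no compound with hydrogen at this carbon has been measured, which leaves the size uncertain.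

A large rise in the number is expected, with compound 4 likely to fall nearer compound 2 than compound 3. The expected move is a 5.0-fold higher number from compound 3 to compound 4 (0.70 log units; beyond the scatter) and it would lie beyond the scatter. Estimated for compound 4 in this assay is 15000 nM with a range from 5000 nM to 45000 nM as the expected bounds.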

Compound 4, half-maximal inhibitory concentration: 6680 nM
Estimate against measurement, compound 4: 2.2-fold (0.35 log units) above; measured number inside the range.
By their numbers in this assay, from the lowest: compounds 1 and 3 (each within the scatter of the next); then compound 4; then compound 2.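

With hydrogen on this carbon as the reference, the two halogens move the number in opposite directions in this assay: chloro gives a modest gain over the plain benzyl (a 2.2-fold higher number from compound 3 to compound 4 (0.35 log units; beyond the scatter)), while fluoro falls on the weaker side of it (a 5.3-fold lower number from compound 2 to compound 4 (0.72 log units; beyond the scatter)), so the larger share of the earlier chloro-to-fluoro gap belongs to fluoro. The level standing of the 4-chlorobenzyl compound with the 5-chlorothiophen-2-yl compound also turns out to depend on the chloro, since the plain benzyl does not keep it (a 4.1-fold higher number from compound 1 to compound 4 (0.61 log units; beyond the scatter)). The data at hand offer no measurement that accounts for this order of chloro, hydrogen and fluoro on the ring.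

Open, going by these compounds, is whether a bromo, methyl or methoxy group on this same carbon would land nearer chloro or nearer fluoro, and whether an amine or a carboxylic acid there would be tolerated at all. Also open, on these data alone, is how a thiophen-2-yl without its chloro would compare with the plain benzyl, which would show whether chloro carries the same weight on both aromatic groups.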